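The source may report more compounds than this note shows. Statements on the series, on what has been measured and on what is new or still open speak of the compounds shown alone.

Compound 2 `CCC1CN2CCC1CC2[C@H](O)c1cc(-c2cccc(C(F)(F)F)c2)nc2ccc(OC)cc12` gives 20000 nM in a functional assay on SK-N-MC cells (Homo sapiens) for inhibition, read by cAMP accumulation; a higher number here means a weaker inhibitor, a lower number a stronger inhibitor. Compound 1 `CCC1CN2CCC1CC2[C@H](O)c1cc(-c2ccc(C(F)(F)F)cc2)nc2ccc(OC)cc12` gives 24000 nM, and the two numbers lie within the usual scatter of each other, so neither stands apart. Among the measured compounds shown here, the only measured step, a 1.2-fold lower number from compound 1 to compound 2 (0.08 log units; within the scatter), exchanged one trifluoromethylphenyl for another. Compound 3 `CCC1CN2CCC1CC2[C@H](O)c1cc(-c2ccc(Cl)cc2Cl)nc2ccc(OC)cc12` carries a different change: 2,4-dichlorophenyl in place of 3-(trifluoromethyl)phenyl on an aromatic carbon. For the measured compounds named here, no measured step exchanges a trifluoromethyl group for chlorine, so there is little to lean on, and the change is expected to give no change at the digits printed from compound 2 to compound 3 (within the scatter) in this assay. Compound 3 is therefore estimated at 20000 nM, with a range from 6000 nM to 60000 nM.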

Compound 3, half-maximal inhibitory concentration: 28000 nM
Compound 3: middle estimate off by 1.4-fold (0.15 log units), on the low side; measured number inside the range.
By their numbers in this assay, from the lowest: compounds 2, 1 and 3 (each within the scatter of the next).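

In this assay, the change to 2,4-dichlorophenyl gives a 1.4-fold higher number from compound 2 to compound 3 (0.15 log units; within the scatter) and a 1.2-fold higher number from compound 1 to compound 3 (0.07 log units; within the scatter) when starting from the other trifluoromethylphenyl compound. At this position, a phenyl ring carrying two chlorines therefore reads no differently from either trifluoromethylphenyl ring, so this swap extends the flat picture beyond trifluoromethyl groups. Nothing measured here offers an explanation for this result.

All three groups are phenyl rings bearing chlorine or trifluoromethyl. From the compounds shown here alone, whether a phenyl ring bearing an amine or a carboxylic acid would move the number remains open.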